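A few compounds are considered here, and "the series" means these few. Any claim that something is new, unique, unknown or untested is made for them only; others in the source may bear on it.

The compounds were tested in a functional assay on MCF7 cells (Homo sapiens) for inhibition, read by CCK-8 assay, with a stated time of 48 h; on this read-out lower numbers stand for stronger inhibition and higher numbers for weaker inhibition. Compound 1 `Cc1ccc(-c2cc3nccc(-c4ccc(F)cc4)n3n2)cc1` reaches only the limit of that assay, > 10000 nM, so no number stands for it. Compound 2 `COc1cc(-c2ccnc3cc(-c4ccc5ccn(C)c5c4)nn23)cc(OC)c1OC` gives 74 nM in this assay, the lowest of the two numbers shown. Among the compounds with values here, compound 3 `COc1cc(-c2ccnc3cc(-c4cn(C(=O)OC(C)(C)C)c5ccccc45)nn23)cc(OC)c1OC` gives 268 nM in this assay, a higher number than compound 2 shows, and the two structures differ in more than one place, so no single step connects them.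

Compound 4 `COc1cc(-c2ccnc3cc(-c4cccc(C#N)c4)nn23)cc(OC)c1OC` has not yet been measured. It keeps the shared core of compound 2 and changes one group on it: 3-cyanophenyl in place of 1-methyl-1H-indol-6-yl on an aromatic carbon. Within the data shown here, no measured pair shows what such an exchange does in this assay, so the expectation rests on the structures alone. The step expected is a 4.1-fold higher number from compound 2 to compound 4 (0.61 log units; beyond the scatter), an upward move in the number, beyond the usual scatter but far from the limit that compound 1 shows. For compound 4 the estimate in this assay is 300 nM, with a range from 80 nM to 1500 nM.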

Compound 4, half-maximal inhibitory concentration: > 10000 nM
Compound 4 ended at the assay's limit; the forecaster's own chance of this, stated with the estimate: 8%; middle value at least 33-fold (1.52 log units) away from the limit.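

Within the data shown here, the exchange of 1-methyl-1H-indol-6-yl for 3-cyanophenyl, on an aromatic carbon of the five-membered aromatic ring with 2 nitrogen, gives the first single-place comparison in this set: an at least 130-fold higher number from compound 2 to compound 4 (2.13 log units; beyond the scatter). With the rest of the molecule unchanged, the group at this position can therefore decide between a measurable number and none at all in this assay. Compound 4 stands at a limit of the assay, not at a number, so the step gives only a minimum size: the limit of > 10000 nM in this assay, at which 2 of the 4 values shown sit.

This one pair cannot separate the loss of the five-membered ring from the arrival of the nitrile. Going by these compounds, it remains open whether a plain phenyl, or a phenyl carrying an amine or a carboxylic acid in place of the nitrile, would bring a number back within the range of the assay.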